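The source may report more compounds than this note shows. Statements on the series, on what has been measured and on what is new or still open speak of the compounds shown alone.

The compounds measured so far:
Compound 1, `CCC(CC)Nc1ncnc2c1ncn2C1O[C@H](C(=O)NCc2ccccc2)[C@@H](O)[C@H]1O`; in an assay with adenosine receptor A1 (Rattus norvegicus) as the target (a higher number here means a weaker inhibitor, a lower number a stronger inhibitor), compound 1 gives 104 nM.
Compound 2, `CCNC(=O)[C@H]1OC(n2cnc3c(NC)ncnc32)[C@H](O)[C@@H]1O`; in this assay compound 2 gives 120 nM.
Compound 3, `CCNC(=O)[C@H]1OC(n2cnc3c(NC(CC)CC)ncnc32)[C@H](O)[C@@H]1O`; in this assay compound 3 gives 1.5 nM.

Compound 3 has the lowest number of the three and is therefore the strongest inhibitor among them; both of its steps to the others lie beyond the scatter. The two steps are a 69-fold lower number from compound 1 to compound 3 (1.84 log units; beyond the scatter) and an 80-fold lower number from compound 2 to compound 3 (1.90 log units; beyond the scatter). Together they show that the group on the amide-type nitrogen and the group on the nitrogen on the aromatic ring each move the number a great deal.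

Compound 4, `C=CCNC(=O)[C@H]1OC(n2cnc3c(NC(CC)CC)ncnc32)[C@H](O)[C@@H]1O`, differs from compound 3 in a single place: vinyl in place of methyl on a saturated chain carbon bound to an amide-type nitrogen. Within the data shown here, the only measured step at this same place is a 69-fold lower number from compound 1 to compound 3 (1.84 log units; beyond the scatter), where a far larger group was exchanged for a smaller one. Among the measured compounds shown here, no measured step traces the exchange of methyl for vinyl itself, so it gives no direct guide. Since the change is small, the expectation is a modest step in this assay, a 1.5-fold higher number from compound 3 to compound 4 (0.17 log units; within the scatter), likely within or near the scatter. Compound 4 is therefore expected to give 2.2 nM, within the range 0.7 nM to 7 nM.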

Compound 4, half-maximal inhibitory concentration: 17 nM
For compound 4 the middle estimate is 7.7-fold (0.89 log units) below the measured one; measured number outside the range, above it.
By their numbers in this assay, from the lowest: compound 3; then compound 4; then compounds 1 and 2 (each within the scatter of the next).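

In this assay, this position proves sensitive even to a small exchange: ethyl to allyl, a change that adds little more than a double bond, gives an 11-fold higher number from compound 3 to compound 4 (1.05 log units; beyond the scatter). The earlier compounds shown here showed only the effect of a much larger exchange, with phenyl in place of methyl on the saturated chain carbon bound to the amide-type nitrogen, whereas vinyl at that place gives an intermediate result, with a 6.1-fold lower number from compound 1 to compound 4 (0.79 log units; beyond the scatter) and the step from compound 3 also beyond the scatter. Among these three compounds, the number therefore rises from methyl through vinyl to phenyl, and no available evidence explains why a change as small as ethyl to allyl moves the number so far.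

The compounds shown leave open whether the larger number follows from the longer chain or from its double bond, a question that a saturated propyl group at the same place would help to separate. They also leave open how a still smaller hydrogen or a branched isopropyl group would compare at this position.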